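The source may hold more compounds than are shown below. What is called first, only, known or untested is meant among the compounds shown, and "the series" means these compounds.

Measured in a functional assay on HEK293 cells for agonist activity at D(4) dopamine receptor (Homo sapiens), read by FLIPR; a lower number here means a smaller maximal response, a higher number a larger maximal response:
- compound 1, `O=C(NCN1CCC(c2cccc[n+]2[O-])CC1)c1ccccc1`: 63%
- compound 2, `CC(C)Oc1cccc(NC(=O)CN2CCC(c3cccc[n+]3[O-])CC2)c1`: 48%
- compound 3, `Cc1cc(F)ccc1NC(=O)CN1CCC(c2cccc[n+]2[O-])CC1`: 84%

Compound 2 stands lowest of the three in this assay. Compound 1 sits higher, beyond the scatter, and compound 3 higher still, beyond the scatter; all three share the same core and differ only in the amide-side group.

Compound 4, `O=C(CN1CCC(c2cccc[n+]2[O-])CC1)Nc1cccc(C(F)(F)F)c1`, is not yet measured. It differs from compound 2 by trifluoromethyl in place of isopropoxy on an aromatic carbon. Among the compounds with values here, no pair among the measured compounds shows this change, so its size is unknown here. A small upward step in this assay is expected, likely near the edge of the scatter, since the other aryl amides all sit above compound 2. Compound 4 is expected to give 60%, between 40% and 85%. The expected step is a number 12 percentage points higher from compound 2 to compound 4 (beyond the scatter).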

Compound 4, largest response reached (reported as efficacy), in percent of the reference or control that the assay uses: 75%
Beside the measured number, compound 4's estimate is 15 percentage points below it, and the stated range covers the measured number.
By their numbers in this assay, from the lowest: compound 2; then compound 1; then compounds 4 and 3 (each within the scatter of the next).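

In this assay, within the data shown here, trifluoromethyl in place of isopropoxy on an aromatic carbon, meta to a large group, gives a number 27 percentage points higher from compound 2 to compound 4 (beyond the scatter) and provides the first readable step at this position. The swap keeps the same count of heavy atoms but removes the hydrogen-bond acceptor of isopropoxy, so the maximal response changes here without a change in that count. No measurement shown explains the step.

Still open, going by these compounds, is where methoxy or nitrile on the same carbon would fall relative to compound 2 and compound 4. On these data alone, whether the step carries over to another ring position also remains unknown.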